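Indolylsulfanyl pyrimidine ureas: step to a pyridinylpiperazine

This account rests on a few compounds, and the source may have more. Where it says the series, first, only, none or still open, it means among the compounds named here.

Measured so far:
compound 1, `Cc1cc(Cl)ccc1NC(=O)Nc1nc(Sc2c[nH]c3ccccc23)cc(N2CCN(Cc3ccccc3)CC2)n1`, 11700 nM
compound 2, `O=C(Nc1ccccc1)Nc1nc(NC2CC2)cc(Sc2c[nH]c3ccccc23)n1`, 14300 nM

Both numbers come from a functional assay on HepG2 cells (Homo sapiens) for inhibition, with a stated time of 72 h; on this read-out higher numbers stand for weaker inhibition and lower numbers for stronger inhibition. Compound 2 gives 14300 nM in this assay, compound 1 gives 11700 nM, and the two lie within the scatter of each other, so neither can be ranked above the other on what is known. Both sit at the weak end of what this assay can report.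

Compound 3, `O=C(Nc1ccccc1)Nc1nc(Sc2c[nH]c3ccccc23)cc(N2CCN(c3ccccn3)CC2)n1`, is not yet measured. It differs from compound 2 in one place: 4-(pyridin-2-yl)piperazin-1-yl in place of cyclopropylamino on an aromatic carbon. Among the measured compounds shown here, no step between two measured compounds isolates this change, so its size is not known from the series. Compound 1 carries a different piperazinyl group on the shared core and shows a number close to that of compound 2, which is the only hint available.

Compound 3 is therefore expected to give about 10000 nM in this assay, between 3000 nM and 30000 nM. The expected step of a 1.4-fold lower number from compound 2 to compound 3 (0.16 log units; within the scatter) is estimated to stay within the scatter, with no direction claimed beyond it.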

Compound 3, half-maximal inhibitory concentration: 8930 nM
Estimate against measurement, compound 3: 1.1-fold (0.05 log units) above, within the range that was stated.
By their numbers in this assay, from the lowest: compounds 3, 1 and 2 (each within the scatter of the next).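

In this assay the exchange of cyclopropylamino for 4-(pyridin-2-yl)piperazin-1-yl on this aromatic carbon gives a 1.6-fold lower number from compound 2 to compound 3 (0.20 log units; within the scatter) and so leaves the two compounds unranked. Among the compounds shown here, this is the first direct reading at this place on the ring: a group of 12 heavy atoms with two rings, 0 hydrogen-bond donors and 3 hydrogen-bond acceptors enters for one of 4 heavy atoms with 1 donor and 1 acceptor, and the number stays within the scatter. No measurement on hand explains why the two numbers stay so close.

Compound 1 differs from compound 3 in more than one place, so the compounds shown do not separate the benzyl and pyridin-2-yl groups on the piperazine from the change on the phenyl of the urea. Also open, going by these compounds, is whether a much smaller dimethylamino group, a morpholin-4-yl ring or a piperazine bearing a carboxylic acid on this carbon would move the number beyond the scatter in this assay or leave it where these compounds sit.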